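A Smaller Silicon Group on the Same Oxygen

The source may hold more compounds than are shown below. What is called first, only, known or untested is meant among the compounds shown, and "the series" means these compounds.

For the measured compounds named here, in a functional assay on P388 cells (Mus musculus) for cytotoxicity, read by sulforhodamine B assay (on this read-out lower numbers stand for an effect already at smaller amounts and higher numbers for an effect only at larger amounts of compound), three related compounds have numbers so far. Compound 1 `C=C1CC[C@@H]2[C@](C)(COC(C)=O)[C@H](OC(C)=O)CC[C@@]2(C)[C@@H]1C/C=C1/C(=O)OC[C@H]1OC(C)=O` gives 1.4 uM, compound 2 `C=C1CC[C@@H]2[C@](C)(CO[Si](C(C)C)(C(C)C)C(C)C)[C@H](OC(C)=O)CC[C@@]2(C)[C@@H]1C/C=C1/C(=O)OC[C@H]1OC(C)=O` gives 1.41 uM, and compound 3 `C=C1CC[C@@H]2[C@](C)(CO)[C@H](OC(C)=O)CC[C@@]2(C)[C@@H]1C/C=C1/C(=O)OC[C@H]1O` gives 4.78 uM. Compound 2 therefore shares the low end of these numbers with compound 1, while compound 3 stands clearly higher. Compound 3 differs from compound 2 in more than one place, so it says little about any single change.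

Compound 4 `C=C1CC[C@@H]2[C@](C)(CO[Si](C)(C)C(C)(C)C)[C@H](OC(C)=O)CC[C@@]2(C)[C@@H]1C/C=C1/C(=O)OC[C@H]1OC(C)=O` has not yet been measured. It differs from compound 2 in one place, on an oxygen on a saturated carbon: a group of 7 heavy atoms (6 carbon, 1 silicon; no ring) in place of a group of 10 heavy atoms (9 carbon, 1 silicon; no ring), on an oxygen on a saturated carbon.

Going by the values given here, the one measured step at this oxygen is a 1.0-fold higher number from compound 1 to compound 2 (0.00 log units; within the scatter). Among the compounds with values here, the group in compound 4 is smaller than the one in compound 2 and larger than the one in compound 1. Those two compounds bracket it in size and show no difference beyond the scatter, so a change here is not expected to matter much. The estimated step is a 1.1-fold higher number from compound 2 to compound 4 (0.03 log units; within the scatter), which means no shift beyond the scatter is expected in this assay. Compound 4 is expected at about 1.5 uM, with an estimated range of 0.7 uM to 3.2 uM.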

Compound 4, concentration for half-maximal effect: 0.34 uM
Beside the measured number, compound 4's estimate is 4.4-fold (0.64 log units) above it; measured number outside the range, below it.
By their numbers in this assay, from the lowest: compound 4; then compounds 1 and 2 (each within the scatter of the next); then compound 3.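

In this assay, this oxygen on a saturated carbon proves sensitive to the group it carries, with a 4.1-fold lower number from compound 2 to compound 4 (0.62 log units; beyond the scatter) and a 4.1-fold lower number from compound 1 to compound 4 (0.61 log units; beyond the scatter). The earlier step, a 1.0-fold higher number from compound 1 to compound 2 (0.00 log units; within the scatter), showed no difference beyond the scatter and gave no sign of this. The numbers also do not follow heavy-atom count in one direction: the group of 7 heavy atoms lies in count between the groups of compound 1 and compound 2, yet compound 4 has a lower number than both, even though the silicon groups of compound 2 and compound 4 have no ring, no hydrogen-bond donors or acceptors and no net charge.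

No available evidence says what lies behind this change. From the compounds shown here alone, it remains open whether a trimethylsilyl group or a benzyl group on the same oxygen would give a number nearer that of compound 4 or nearer those of compound 1 and compound 2.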